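The compounds below may be only part of what the source reports. "The series", "measured", "known", "first", "only" and "open" are said of these compounds alone.

Of the compounds shown here, two have so far been measured in an assay on isolated protein for agonist activity at Bile acid receptor (Homo sapiens), read by TR-FRET, with a stated time of 3 h, in the absence of a further agent; on this read-out higher numbers stand for an effect only at larger amounts of compound and lower numbers for an effect already at smaller amounts. Compound 1 `Cc1ccc(NC(=O)c2ccc(Oc3ccccc3)cc2)cc1C(=O)O` gives 127 nM in this assay. Compound 2 `CCOc1cccc(C(=O)Nc2cccc(C(=O)O)c2)c1` gives 2350 nM in this assay, the higher of the two numbers, and its gap to compound 1 lies beyond the scatter. Compound 3 `CC(C)COc1cccc(C(=O)Nc2cccc(C(=O)O)c2)c1` is not yet measured; it differs from compound 2 by isopropyl in place of methyl on a saturated chain carbon bound to an oxygen on an aromatic ring. For the measured compounds named here, no measured pair shows this change. The lower number belongs to compound 1, which carries the larger substituent, at 127 nM. A modest step toward lower numbers is therefore expected, a 2.4-fold lower number from compound 2 to compound 3 (0.37 log units; beyond the scatter). For compound 3 the estimated value in this assay is 1000 nM, within a range from 300 nM to 4000 nM.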

Compound 3, half-maximal effective concentration: 1130 nM
Beside the measured number, compound 3's estimate is 1.1-fold (0.05 log units) below it; the measured number falls inside the stated range.
By their numbers in this assay, from the lowest: compound 1; then compound 3; then compound 2.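

In this assay, for the compounds shown here, isopropyl in place of methyl on a saturated chain carbon bound to an oxygen on an aromatic ring gives a 2.1-fold lower number from compound 2 to compound 3 (0.32 log units; beyond the scatter), the first reading of any change at this position. Going from ethoxy to isobutoxy therefore lowers the number modestly in this one pair, with the step beyond the scatter. No available data explain this step.

From the compounds shown here alone, whether a longer chain, a cyclohexyl group or an amine at this position would lower the number further remains open. So does whether the same change would have a similar effect in other compounds of the series.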